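Amino for Nitro on a Fused Ring: Cytotoxicity Outlook

The compounds below may be only part of what the source reports. "The series", "measured", "known", "first", "only" and "open" are said of these compounds alone.

Compound 1 `CCn1cc(-c2nc3ccccc3s2)c(=O)c2cc(F)c(N3CCN(C)CC3)cc21` gives 24000 nM in a functional assay on Bel-7402 cells (Homo sapiens) for cytotoxicity, read by MTT assay, with a stated time of 48 h; on this read-out higher numbers stand for weaker inhibition and lower numbers for stronger inhibition.
Compound 2 `CCn1cc(-c2nc3ccc([N+](=O)[O-])cc3[nH]2)c(=O)c2cc(F)c(N3CCN(C)CC3)cc21` gives 4400 nM in this assay.

Of the two numbers measured, compound 2 stands at the lower one, and the gap to compound 1 lies beyond the usual scatter of repeated measurements. Among the compounds with values here, no pair of measured compounds differs in a single place, so no measured step is available to guide the next change.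

Compound 3 `CCn1cc(-c2nc3ccc(N)cc3[nH]2)c(=O)c2cc(F)c(N3CCN(C)CC3)cc21` differs from compound 2 in one place:

amino in place of nitro on an aromatic carbon

Within the data shown here, the data give no measured step of this kind, so the direction cannot be read from the two numbers at hand. The step of a 1.4-fold higher number from compound 2 to compound 3 (0.13 log units; within the scatter) is expected to be small, likely not beyond the scatter, with a wide spread either way. Compound 3 is estimated at 6000 nM in this assay, with a range from 1500 nM to 25000 nM.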

Compound 3, half-maximal inhibitory concentration: > 50000 nM
Compound 3: only a limit was reported; the forecaster's own chance of this, stated with the estimate: 10%; middle value at least 8.3-fold (0.92 log units) away from the limit.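

At this position the group matters far more than the two earlier compounds could show: amino in place of nitro on the aromatic carbon gives an at least 11-fold higher number from compound 2 to compound 3 (1.05 log units; beyond the scatter). Replacing the whole fused group of compound 1 with the amino-bearing one gives an at least 2.0-fold higher number from compound 1 to compound 3 (0.31 log units; beyond the scatter), so the lower number of compound 2 does not carry over to this fused group once nitro has left. In this assay the reading for compound 3 is a limit and not a number: the limit of > 50000 nM in this assay, at which 1 of the 3 values shown sits.

Going by these compounds, how far compound 3 lies past that limit remains open, so the full size of both steps is unknown. On these data alone, it is also open whether a nitrile or a carboxylic acid on the same aromatic carbon would read closer to compound 2 or to compound 3.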